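Cytotoxicity outlook for a benzylsulfanyl analogue

The source may report more compounds than this note shows. Statements on the series, on what has been measured and on what is new or still open speak of the compounds shown alone.

Of the compounds shown here, three on the shared core have been measured in an ADME assay on Akata cells (Homo sapiens) for cytotoxicity, with a stated time of 7 days; on this read-out higher numbers stand for lower toxicity in this test and lower numbers for higher toxicity in this test. Compound 1 `Nc1nc2c(ncn2/C=C2/CC2(CO)CO)c(=O)[nH]1` is the simplest member; in this assay compound 1 gives only > 20000 nM, which is a limit of the test rather than a number. Compound 2 `Nc1nc(NC2CCCCC2)c2ncn(/C=C3/CC3(CO)CO)c2n1` bears a cyclohexylamino group; in this assay compound 2 likewise stops at a limit, > 24000 nM. Compound 3 `Nc1nc(SC2CCCC2)c2ncn(/C=C3/CC3(CO)CO)c2n1` bears a cyclopentylsulfanyl group, and in this assay compound 3 also reaches only a limit, > 20000 nM. Compound 2 therefore stands at a limit, as do both other values shown, so no order among the three can be read. Accordingly the step that the two limits leave unreadable from compound 2 to compound 3 has no readable size. Compound 4 `Nc1nc(SCc2ccccc2)c2ncn(/C=C3/CC3(CO)CO)c2n1` differs from compound 2 by benzylsulfanyl in place of cyclohexylamino on an aromatic carbon. Among the compounds with values here, the only related change, cyclopentylsulfanyl for cyclohexylamino, left the read-out at a limit, as the limit of > 20000 nM in this assay, at which 2 of the 3 values shown sit, and the limit of > 24000 nM in this assay, at which 1 of the 3 values shown sits, show, and nothing here points to a step beyond the scatter. Compound 4 is thus expected to lie near the limit too, at about 30000 nM (between 15000 nM and 60000 nM). The expected step that the limit leaves unreadable from compound 2 to compound 4 is essentially none.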

Compound 4, half-maximal cytotoxic concentration: > 20000 nM
Compound 4 ended at the assay's limit; the forecaster's own chance of this, stated with the estimate: 85%; the middle value does not contradict the limit.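

In this assay compound 4 gives > 20000 nM, which is a limit of the test. Compound 2 and compound 3 also stand at limits, so neither step to compound 4 can be read. The compounds shown leave open what concentration would reach half-maximal cytotoxicity for any of them.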